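Butoxy to methyl exchange across two related cores

A few compounds are considered here, and "the series" means these few. Any claim that something is new, unique, unknown or untested is made for them only; others in the source may bear on it.

Compound 1 `CCCCOc1ccccc1C[C@H]1C(=O)OC[C@@H]1Cc1ccccc1` carries a butoxy group on one of its aromatic rings. In a functional assay on HL-60 cells (Homo sapiens) for cytotoxicity, read by WST assay, with a stated time of 48 h (on this read-out higher numbers stand for an effect only at larger amounts of compound and lower numbers for an effect already at smaller amounts), compound 1 gives 20000 nM. Compound 2 `Cc1ccccc1C[C@H]1C(=O)OC[C@@H]1Cc1ccccc1` differs from it by methyl in place of butoxy on an aromatic carbon; in this assay compound 2 gives 57000 nM, which is a step of a 2.9-fold higher number from compound 1 to compound 2 (0.45 log units; beyond the scatter). Compound 3 `CCCCOc1ccccc1C[C@H]1COC[C@@H]1Cc1ccc(Cl)c(Cl)c1` sits on a different core; the difference between the two cores is not broken down here. In this assay compound 3 gives 20000 nM, level with compound 1. Compound 4 `Cc1ccccc1C[C@H]1COC[C@@H]1Cc1ccc(Cl)c(Cl)c1` has not yet been measured and differs from compound 3 by methyl in place of butoxy on an aromatic carbon, the same change as that made from compound 1 to compound 2, with the place described in the same words for both pairs. For the measured compounds named here, only a single measured instance of this change exists, so the expectation for compound 4 rests on that one step alone. From compound 3 to compound 4 a step of about a 2.8-fold higher number from compound 3 to compound 4 (0.44 log units; beyond the scatter) is expected because of a 2.9-fold higher number from compound 1 to compound 2 (0.45 log units; beyond the scatter) seen on the other core. Compound 4 is therefore estimated at 55000 nM in this assay, with a range from 25000 nM to 120000 nM.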

Compound 4, half-maximal effective concentration: 21000 nM
Compound 4: middle estimate off by 2.6-fold (0.42 log units), on the high side; the measured number lies below the stated range.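

In this assay, methyl in place of butoxy on the core of compound 3 gives a 1.1-fold higher number from compound 3 to compound 4 (0.02 log units; within the scatter), so on this core the exchange leaves the read-out within the scatter. Set beside the earlier step, the exchange does not carry over in size from one core to the other: the same change on two cores in this assay, a 2.9-fold higher number (0.45 log units; beyond the scatter) from compound 1 to compound 2 and a 1.1-fold higher number (0.02 log units; within the scatter) from compound 3 to compound 4, 2.7-fold (0.43 log units) apart, beyond the scatter of two such steps. For the compounds shown here, the step seen on one core is therefore a poor guide on its own to the same exchange on another core, but with only one pair per core these results do not show which feature of the cores goes with the gap, or how other exchanges would carry over.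

The compounds shown leave open how the read-out follows the group at this place on either core, for instance with ethoxy, a longer chain such as hexyloxy, an amine or a carboxylic acid. Also open, on these data alone, is how the exchange behaves on cores carrying only part of the difference between the two cores.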